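Working notes on cytotoxicity, compound 3 to compound 4

The source may report more compounds than this note shows. Statements on the series, on what has been measured and on what is new or still open speak of the compounds shown alone.

Measured in a functional assay on ME18 cells (Homo sapiens) for cytotoxicity, read by MTT assay, with a stated time of 48 h (on this read-out higher numbers stand for weaker inhibition and lower numbers for stronger inhibition), so far:
compound 1 `Cc1ccc(C(c2c[nH]c3ccccc23)c2c[nH]c3ccccc23)cc1`: 46700000 nM
compound 2 `Cc1ccc(C(c2c[nH]c3ccc(I)cc23)c2c[nH]c3ccc(I)cc23)cc1`: 22600000 nM
compound 3 `COc1ccc2[nH]cc(C(c3ccc(C)cc3)c3c[nH]c4ccc(OC)cc34)c2c1`: 32900000 nM

Compound 3 sits with the other two: its number lies within the usual scatter of compound 1 and likewise within the scatter of compound 2, so the three measured values in this assay cannot be told apart. Compound 1 and compound 2 differ only on their shared core, not at the position now in question, and their two numbers also fall within scatter of each other.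

Compound 4 `COc1ccc2[nH]cc(C(c3cc(F)cc(F)c3)c3c[nH]c4ccc(OC)cc34)c2c1` is not yet measured. It differs from compound 3 by 3,5-difluorophenyl in place of 4-methylphenyl on a saturated chain carbon bound to two aromatic carbons. Going by the values given here, no measured pair shows this exchange, so nothing speaks for a shift in either direction. The step from compound 3 to compound 4 in this assay is therefore expected to be a 1.1-fold lower number from compound 3 to compound 4 (0.04 log units; within the scatter), none beyond the scatter. Compound 4 is estimated at 30000000 nM in this assay, with a plausible range from 10000000 nM to 90000000 nM.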

Compound 4, half-maximal inhibitory concentration: 28400000 nM
Compound 4: middle estimate off by 1.1-fold (0.02 log units), on the high side, within the range that was stated.
By their numbers in this assay, from the lowest: compounds 2, 4, 3 and 1 (each within the scatter of the next, the first and the last beyond it).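

In this assay, replacing 4-methylphenyl with 3,5-difluorophenyl on a saturated chain carbon bound to two aromatic carbons gives a 1.2-fold lower number from compound 3 to compound 4 (0.06 log units; within the scatter). Going by these compounds alone, this is the only reading of a change at this position, and it shows that a carbon-only aromatic ring carrying two fluorine atoms can stand in place of one carrying a methyl group without a step beyond the scatter. Nothing at hand bears on why the exchange reads this way.

Still open, going by these compounds, is whether a group of another kind at this position, such as an amine, a carboxylic acid or a longer chain, would move the number beyond the scatter. Also open, on these data alone, is whether the same exchange would read alike on the core of compound 1 or of compound 2.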